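A propylsulfonyl group enters the series

The compounds below may be only part of what the source reports. "The series", "measured", "known", "first", "only" and "open" are said of these compounds alone.

In a physicochemical assay for lipophilicity, using the shake flask method (on this read-out higher numbers stand for higher lipophilicity and lower numbers for lower lipophilicity), compound 3 `O=C(Nc1ccc(C(F)(F)F)cc1)NC1CCN(C(=O)CCC(F)(F)F)CC1` gives 3.66. Within the data shown here, the only other measured compound, compound 2 `CC(C)CC(=O)N1CCC(NC(=O)Nc2ccc(C(F)(F)F)cc2)CC1`, gives 3.86, and these two numbers lie within the scatter of each other. Compound 1 `CCCC(=O)N1CCC(NC(=O)Nc2ccc(C(F)(F)F)cc2)CC1` offers no comparison, since the entry for compound 1 reads "not determined" (no result reported).

Compound 4 `CCCS(=O)(=O)N1CCC(NC(=O)Nc2ccc(C(F)(F)F)cc2)CC1` keeps the shared core and differs from compound 3 in one place, with propylsulfonyl in place of (3,3,3-trifluoropropyl)carbonyl on an amine nitrogen in a ring.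

Just one measured step offers any guidance: a number 0.20 log units lower from compound 2 to compound 3 (within the scatter). It put 2,2,2-trifluoroethyl in place of isopropyl on a saturated chain carbon bound to a carbonyl carbon. That step stayed small, but the carbonyl remained in place, whereas compound 4 has lost it. Among the measured compounds shown here, no measured pair shows a carbonyl group exchanged for a sulfonyl group, so the guidance is weak and the range must stay wide. In this assay, no change beyond the scatter is expected. The expected step is a number 0.16 log units lower from compound 3 to compound 4 (within the scatter). For compound 4 the estimated value is 3.5, with an expected range from 3 to 4.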

Compound 4, partition coefficient: 3.39
Estimate against measurement, compound 4: 0.11 log units above; the range from low to high includes it.
By their numbers in this assay, from the lowest: compounds 4, 3 and 2 (each within the scatter of the next, the first and the last beyond it).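

Among these compounds, compound 4 brings a sulfonyl group onto an amine nitrogen in a ring, a kind of exchange that the earlier compounds did not cover, and in this assay the outcome depends on which carbonyl group it is compared with. Measured against (3,3,3-trifluoropropyl)carbonyl, propylsulfonyl gives a number 0.27 log units lower from compound 3 to compound 4 (within the scatter) and so cannot be told apart from that group here. Measured against isobutylcarbonyl, the same group gives a number 0.47 log units lower from compound 2 to compound 4 (beyond the scatter), a modest step and the only one shown so far that passes beyond the scatter, so changing the group at this position can shift the read-out by a measurable amount.

Nothing available explains either step. On these data alone, compound 1 carries a propyl chain on a carbonyl and would give the closest comparison with compound 4, but its entry has no result, so steps involving it cannot be read, and it remains open how a sulfonyl group with a longer chain, or isobutylsulfonyl, would compare at this position.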